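This account rests on a few compounds, and the source may have more. Where it says the series, first, only, none or still open, it means among the compounds named here.

Measured so far:
compound 1, `COc1cc(C(=O)n2ccc3ccccc32)cc(OC)c1OC` — in a functional assay on NCI-H460 cells (Homo sapiens) for inhibition, with a stated time of 72 h (on this read-out lower numbers stand for stronger inhibition and higher numbers for weaker inhibition), compound 1 gives > 10000 nM, a limit of the assay and not a number.
compound 2, `COc1cc(C(=O)c2ccc3[nH]ccc3c2)cc(OC)c1OC` — in this assay compound 2 gives 112 nM.

Compound 2 thus holds the only number shown in this assay; the other value is a limit (the limit of > 10000 nM in this assay, at which 1 of the 2 values shown sits). Among the measured compounds shown here, no two measured compounds differ in a single place, so no measured step is known. Compound 3, `CCCn1ccc2cc(C(=O)c3cc(OC)c(OC)c(OC)c3)ccc21`, differs from compound 2 by propyl in place of hydrogen on an aromatic nitrogen. For the measured compounds named here, no measured step bears on this change, so in this assay none beyond the scatter is expected in either direction. The expected step of a 1.0-fold lower number from compound 2 to compound 3 (0.01 log units; within the scatter) is accordingly small. Compound 3 is expected to give 110 nM, within 30 nM to 450 nM.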

Compound 3, half-maximal inhibitory concentration: 2000 nM
The estimate for compound 3 lay 18-fold (1.26 log units) below the measured number, outside the stated range (above it).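

In this assay, the aromatic nitrogen of the five-membered ring now has a measured step: propyl in place of hydrogen gives an 18-fold higher number from compound 2 to compound 3 (1.25 log units; beyond the scatter), which means weaker inhibition. Compound 3 still gives a number, 2000 nM, and not a limit, so propyl at this nitrogen weakens inhibition without removing it from the measurable range. Nothing shown accounts for the size of this step.

As far as these compounds go, whether the loss belongs to propyl or to any group replacing this hydrogen stays open. Methyl, a longer chain or a chain ending in an amine at this nitrogen could separate these cases.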